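This account rests on a few compounds, and the source may have more. Where it says the series, first, only, none or still open, it means among the compounds named here.

The account concerns a set of dichloroacetamides on a shared core and the measurements made in a functional assay on NCI-H460 cells (Homo sapiens) for cytotoxicity, read by MTT assay, with a stated time of 68 h; a higher number here means a weaker inhibitor, a lower number a stronger inhibitor. Compound 1 `Nc1cccc(-c2cccc(NC(=O)C(Cl)Cl)c2)c1` stands at the lower edge of what the assay can resolve: in this assay compound 1 gives only a limit, > 50000 nM, and no number. Compound 3 `CSc1ccccc1-c1cc(NC(=O)C(Cl)Cl)cc(-c2ccccc2SC)c1` likewise yields only a limit in this assay, > 30000 nM. Among the measured compounds shown here, compound 2 `O=C(Nc1cccc(-c2ccc(-c3ccccc3)cc2)c1)C(Cl)Cl` is the one member with a resolved value, giving 10900 nM in this assay.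

Compound 4 `O=C(Nc1cccc(-c2cccc(C(F)(F)F)c2)c1)C(Cl)Cl` has not been measured. It differs from compound 1 in one place: trifluoromethyl in place of amino on an aromatic carbon. For the measured compounds named here, no step between measured compounds is on record, so the size of this step can only be expected, not read off. With compound 2 at 10900 nM showing that a resolved value within this core is possible, a modest step toward stronger inhibition is expected. From the compounds shown here alone, whether compound 4 will in fact be resolved by the assay remains open. Compound 4 is expected to give 20000 nM, within a range from 5000 nM to 60000 nM. The expected step of an at least 2.5-fold lower number from compound 1 to compound 4 (0.39 log units; beyond the scatter) is toward stronger inhibition.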

Compound 4, half-maximal inhibitory concentration: 30200 nM
Compound 4: the middle estimate sits 1.5-fold (0.18 log units) below what was measured; the range from low to high includes it.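

Among the compounds shown here, at this position, meta to a large group, the change from amino to trifluoromethyl gives the first single-place comparison, and compound 4 has a resolved value in this assay where compound 1 has none. The change amounts to an at least 1.6-fold lower number from compound 1 to compound 4 (0.21 log units; that floor lies within the scatter). This figure is a floor and not a full size, and the direction is firm only as far as that floor allows, because compound 1 gives only a limit: the limit of > 50000 nM in this assay, at which 1 of the 4 values shown sits.

From the compounds shown here alone, whether a nitrile or a carboxylic acid on the same aromatic carbon would also give a resolved value in this assay remains open. Going by these compounds, with a single pair in hand, it is also open whether trifluoromethyl would have a comparable effect elsewhere on the shared core.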